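The source may report more compounds than this note shows. Statements on the series, on what has been measured and on what is new or still open speak of the compounds shown alone.

Three ureas built on one shared core have been measured in a functional assay on HepG2 cells (Homo sapiens) for inhibition, read by MTT assay, with a stated time of 72 h; on this read-out higher numbers stand for weaker inhibition and lower numbers for stronger inhibition. Compound 1 `O=C(Nc1cccc(OCc2cn(-c3ccccc3)nn2)c1)Nc1ccc(Cl)c(C(F)(F)F)c1` gives 1780 nM in this assay. Compound 2 `Cc1ccccc1-n1cc(COc2cccc(NC(=O)Nc3ccc(Cl)c(C(F)(F)F)c3)c2)nn1` gives 3440 nM in this assay. Compound 3 `N#Cc1ccccc1-n1cc(COc2cccc(NC(=O)Nc3ccc(Cl)c(C(F)(F)F)c3)c2)nn1` gives 1970 nM in this assay. Among these three numbers compound 3 stands second highest, nearest to compound 1 and furthest from compound 2, yet both gaps lie within the scatter, so none of the three can be told apart on these data. The step of a 1.9-fold higher number from compound 1 to compound 2 (0.29 log units; within the scatter) was within the scatter, and so was the step of a 1.1-fold higher number from compound 1 to compound 3 (0.04 log units; within the scatter).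

Compound 4 `CCc1ccccc1-n1cc(COc2cccc(NC(=O)Nc3ccc(Cl)c(C(F)(F)F)c3)c2)nn1` has not yet been measured. It differs from compound 3 in one place: ethyl in place of cyano on an aromatic carbon. The step that bears most directly on this change is a 1.7-fold lower number from compound 2 to compound 3 (0.24 log units; within the scatter), since ethyl resembles methyl more than it resembles cyano, and its reverse is the nearest guide; it was within the scatter, as were the other two steps. In this assay the expected step is therefore a 1.5-fold higher number from compound 3 to compound 4 (0.18 log units; within the scatter), a somewhat higher number that is expected to remain within the scatter. The estimate for compound 4 is 3000 nM, with a range from 1400 nM to 6500 nM.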

Compound 4, half-maximal inhibitory concentration: 3530 nM
Estimate against measurement, compound 4: 1.2-fold (0.07 log units) below; the measured number falls inside the stated range.
By their numbers in this assay, from the lowest: compounds 1, 3, 2 and 4 (each within the scatter of the next).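

In this assay, the exchange of 2-cyanophenyl for 2-ethylphenyl gives the step (a 1.8-fold higher number from compound 3 to compound 4 (0.25 log units; within the scatter)), and extending methyl to ethyl gives the step (a 1.0-fold higher number from compound 2 to compound 4 (0.01 log units; within the scatter)), so at this position, ortho to a large group, ethyl cannot be told apart from either cyano or methyl. The comparison with the unsubstituted compound gives the step (a 2.0-fold higher number from compound 1 to compound 4 (0.30 log units; within the scatter)), which is also printed as within the scatter, so hydrogen, methyl, cyano and ethyl at this one place all give numbers that these data cannot separate, and this holds for a group with no hydrogen-bond acceptor as well as for cyano, which has one. No measured evidence on any property of these groups accompanies these numbers, so the result stands as a set of values without an explanation.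

The compounds shown leave open whether a different kind of group at this place, such as an amine, a carboxylic acid or a longer chain like butyl, would give a step beyond the scatter. They also leave open whether ethyl or cyano would behave the same way elsewhere on this six-membered aromatic ring.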